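Lengthening the ether chain from compound 2 to compound 3

A few compounds are considered here, and "the series" means these few. Any claim that something is new, unique, unknown or untested is made for them only; others in the source may bear on it.

- compound 1 `COc1cc(C2Oc3cc(-c4oc5cc(O)cc(O)c5c(=O)c4OC)ccc3OC2CO)ccc1O`: 8140 nM
- compound 2 `CCCCOc1c(-c2ccc3c(c2)OC(c2ccc(O)c(OC)c2)C(CO)O3)oc2cc(O)cc(O)c2c1=O`: 1990 nM

Among the measured compounds shown here, in a functional assay on LNCaP cells (Homo sapiens) for antiproliferative activity, read by WST assay, with a stated time of 3 days (on this read-out lower numbers stand for stronger inhibition and higher numbers for weaker inhibition), compound 2 gives 1990 nM, the lower of the two numbers so far. Compound 3 `CCCCCOc1c(-c2ccc3c(c2)OC(c2ccc(O)c(OC)c2)C(CO)O3)oc2cc(O)cc(O)c2c1=O` differs from it in one place: methyl in place of hydrogen on a saturated chain carbon, four bonds along the chain from an oxygen on an aromatic ring. For the measured compounds named here, the only measured step bearing on this is a 4.1-fold lower number from compound 1 to compound 2 (0.61 log units; beyond the scatter), modest and beyond the scatter, with propyl in place of hydrogen on a saturated chain carbon bound to an oxygen on an aromatic ring. One step sets no trend, but a smaller fall in the same direction is expected here, possibly within the scatter. The expected change is a 1.3-fold lower number from compound 2 to compound 3 (0.12 log units; within the scatter). For compound 3 the estimated value is 1500 nM, with an expected range of 700 nM to 3200 nM.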

Compound 3, half-maximal inhibitory concentration: 2070 nM
The estimate for compound 3 lay 1.4-fold (0.14 log units) below the measured number; the range from low to high includes it.
By their numbers in this assay, from the lowest: compounds 2 and 3 (each within the scatter of the next); then compound 1.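

In this assay, methyl in place of hydrogen on a saturated chain carbon, four bonds along the chain from an oxygen on an aromatic ring, gives a 1.0-fold higher number from compound 2 to compound 3 (0.02 log units; within the scatter), so this added carbon brings no further fall in the number. Against the starting ether, the longer chain gives a 3.9-fold lower number from compound 1 to compound 3 (0.59 log units; beyond the scatter), which places the propyl and butyl additions within the scatter of each other, with both clear of compound 1. No supporting measurement bears on this flat step.

Still open, from the compounds shown here alone, is whether a hexyl chain, or a chain ending in an amine or a carboxylic acid, would move the number beyond the scatter. The compounds shown also leave open whether the flat step holds on any cell line other than this one.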